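From 1H-imidazol-1-yl to 5-methyl-1H-imidazol-1-yl

The source may report more compounds than this note shows. Statements on the series, on what has been measured and on what is new or still open speak of the compounds shown alone.

In a functional assay on the whole organism for agonist activity, with Mus musculus as the target (on this read-out higher numbers stand for an effect only at larger amounts of compound and lower numbers for an effect already at smaller amounts), compound 1 (`CCOC(=O)N(C)C(C)C#CCN1CCCC1`) gives > 100 mg/kg as a limit and not a number. Compound 2 (`CCOC(=O)N(C)C(C)C#CCn1ccnc1`) gives > 100 mg/kg as a limit too, so its standing is known only as the limit of > 100 mg/kg in this assay, at which 2 of the 2 values shown sit, and nothing finer. Among the compounds with values here, the one measured step is a step that the two limits leave unreadable from compound 1 to compound 2 and offers no size to carry forward. The change to compound 3 (`CCOC(=O)N(C)C(C)C#CCn1cncc1C`) is methyl in place of hydrogen on an aromatic carbon and turns 1H-imidazol-1-yl into 5-methyl-1H-imidazol-1-yl. With no readable step to scale from, the series gives no firm direction, and a further limit in this assay is the likeliest outcome. The expected change is a step that the limit leaves unreadable from compound 2 to compound 3 as a rough working figure only. For compound 3 the estimated dose is 150 mg/kg with an expected range of 50 mg/kg to 400 mg/kg in this read-out.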

Compound 3, dose for half-maximal effect: > 100 mg/kg
Compound 3 was reported as a limit; the forecaster's own chance of this, stated with the estimate: 75%; the middle value does not contradict the limit.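

Compound 1, compound 2 and compound 3 give no readable step in this assay, as each value is a limit and not a number: the limit of > 100 mg/kg in this assay, at which 3 of the 3 values shown sit.

The compounds shown leave open how the pyrrolidin-1-yl, 1H-imidazol-1-yl and 5-methyl-1H-imidazol-1-yl groups compare in dose for half-maximal effect.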